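The source may report more compounds than this note shows. Statements on the series, on what has been measured and on what is new or still open speak of the compounds shown alone.

Of the compounds shown here, two have been measured so far. Compound 1 `COc1cccc(Nc2nc3cccc(-c4c(F)cccc4OC)c3o2)n1` gives 620 nM in an assay on isolated protein for inhibition of ribosomal protein S6 kinase alpha-2 (Homo sapiens), with a stated time of 150 min; on this read-out higher numbers stand for weaker inhibition and lower numbers for stronger inhibition. Compound 2 `COc1ccccc1-c1cccc2nc(Nc3cc(OC)c(OC)c(OC)c3)oc12` gives 20 nM in this assay, the lower of the two numbers, and its gap to compound 1 lies beyond the usual scatter. The next compound, compound 3 `COc1ccc(F)cc1-c1cccc2nc(Nc3cc(OC)c(OC)c(OC)c3)oc12`, has not yet been measured. It differs from compound 2 in a single place: fluoro in place of hydrogen on an aromatic carbon. Going by the values given here, the change is small in size, adding one fluorine and nothing else, and no comparable step between two measured compounds is available here to guide the reading. The account therefore expects no shift beyond the scatter, and the estimated step of no change at the digits printed from compound 2 to compound 3 (within the scatter) reflects that. For compound 3 the expected value in this assay is 20 nM, with a plausible range from 7 nM to 60 nM.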

Compound 3, half-maximal inhibitory concentration: 40 nM
Compound 3: middle estimate off by 2.0-fold (0.30 log units), on the low side; measured number inside the range.
By their numbers in this assay, from the lowest: compounds 2 and 3 (each within the scatter of the next); then compound 1.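

In this assay, going by these compounds alone, fluoro in place of hydrogen on an aromatic carbon, para to the methoxy group of the 2-methoxyphenyl ring, gives a 2.0-fold higher number from compound 2 to compound 3 (0.30 log units; within the scatter) and is the first step that changes one place only. At this position a single fluorine therefore leaves the number within the scatter, and 2-methoxyphenyl and 5-fluoro-2-methoxyphenyl cannot be told apart on this read-out. No measurement at hand bears on why this is so.

From the compounds shown here alone, whether this carbon would read the same with a chlorine, a nitrile or an amine in place of the fluorine remains open. So does whether fluoro on the other carbons of this ring would stay within the scatter as well.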